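A few compounds are considered here, and "the series" means these few. Any claim that something is new, unique, unknown or untested is made for them only; others in the source may bear on it.

Compound 1 `Cn1nc(C(F)(F)F)cc1C(=O)Nc1ccc(S(=O)(=O)n2ccc3ccccc32)cc1` gives 13000 nM
Compound 2 `Cn1nc(C(F)(F)F)cc1C(=O)Nc1ccc(S(=O)(=O)N2CCN(C(=O)OC(C)(C)C)CC2)cc1` gives > 300000 nM (a limit, not a number)

Both compounds were tested in an ADME assay on Vero cells (Chlorocebus sabaeus) for cytotoxicity, read by MTT assay (on this read-out lower numbers stand for higher toxicity in this test and higher numbers for lower toxicity in this test), and share most of their structure. Within the data shown here, compound 1 holds the only actual number here, with its 13000 nM as the single measured concentration. Compound 2 reads > 300000 nM as a limit of the assay and not a number.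

Compound 3 `Cn1nc(C(F)(F)F)cc1C(=O)Nc1ccc(S(=O)(=O)N2CCC(N)CC2)cc1` has not yet been measured. It carries 4-aminopiperidin-1-yl in place of 1H-indol-1-yl on a sulfonyl sulfur and otherwise keeps the core of compound 1.

Among the measured compounds shown here, no measured step bears directly on this change, so the only guide is a loose comparison. Compound 2 also lacks the 1H-indol-1-yl and gives > 300000 nM as a limit of the assay. On that single comparison, a sizeable step toward a higher number is expected in this assay and would mean lower toxicity in this test. The estimated step of a 7.7-fold higher number from compound 1 to compound 3 (0.89 log units; beyond the scatter) is therefore upward but uncertain. For compound 3 the estimated value is 100000 nM with an expected range from 30000 nM to 300000 nM in this test.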

Compound 3, half-maximal cytotoxic concentration: > 300000 nM
Compound 3: only a limit was reported (the forecaster's own chance of this, stated with the estimate: 25%); at least 3.0-fold (0.47 log units) between middle value and limit.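

In this assay, among these compounds, 4-aminopiperidin-1-yl in place of 1H-indol-1-yl on a sulfonyl sulfur gives an at least 23-fold higher number from compound 1 to compound 3 (1.36 log units; beyond the scatter), the first step that can be read at this position, and it lies beyond the scatter. As far as these compounds go, compound 3 gives > 300000 nM, which is a limit of the assay and not a number, so the step gives only the smallest size the change can have and its full size stays unknown. Compound 3 and compound 2 cannot be ranked against each other in this assay, and the top of the scale caps the comparison: the limit of > 300000 nM in this assay, at which 2 of the 3 values shown sit.

The change swaps the two aromatic rings of 1H-indol-1-yl for a non-aromatic ring and brings in an amine at the same time, so the compounds shown leave open which of the two goes with the step, a question that a plain piperidin-1-yl without the amine would address. They also leave open whether an aromatic group smaller than 1H-indol-1-yl, such as an anilino group, on the same sulfonyl sulfur would give a number below the limit.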